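Chlorophenyl in Place of Methylfuran on the Shared Core

The compounds below may be only part of what the source reports. "The series", "measured", "known", "first", "only" and "open" are said of these compounds alone.

Compound 1 `Clc1ccc(-c2cc(-c3ccoc3)cc(-c3cccs3)n2)cc1` and compound 2 `Cc1ccc(-c2cc(-c3ccc(Cl)o3)cc(-c3ccsc3)n2)o1` share one core carrying three aromatic rings. In a functional assay on HCT-15 cells (Homo sapiens) for cytotoxicity, in the presence of a further agent that is not named here (a lower number here means a stronger inhibitor, a higher number a weaker inhibitor), compound 1 gives 50000 nM. Compound 2 gives > 50000 nM in this assay, and that figure is a limit of the assay rather than a measured number. Of the two values shown, one sits at that limit (the limit of > 50000 nM in this assay, at which 1 of the 2 values shown sits).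

Compound 3 `Clc1ccc(-c2cc(-c3ccc(Cl)o3)cc(-c3ccsc3)n2)cc1` differs from compound 2 in one place: 4-chlorophenyl in place of 5-methylfuran-2-yl on an aromatic carbon. Among the measured compounds shown here, no measured pair of compounds shows this change, so its size cannot be read from a comparison; the only guide is that compound 1, which also carries a 4-chlorophenyl group, gives 50000 nM in this assay. The step from compound 2 to compound 3 is therefore expected to be a number no higher from compound 2 to compound 3 (the limit leaves the size open), nothing beyond the usual scatter. Compound 3 is estimated at 50000 nM, within 20000 nM to 150000 nM, with a real chance that this assay again returns only a limit.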

Compound 3, half-maximal inhibitory concentration: 5190 nM
The estimate for compound 3 lay 9.6-fold (0.98 log units) above the measured number; measured number below the stated range.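

In this assay, putting 4-chlorophenyl in place of 5-methylfuran-2-yl on the aromatic carbon next to the ring nitrogen gives an at least 9.6-fold lower number from compound 2 to compound 3 (0.98 log units; beyond the scatter). Among the compounds shown here, with the 5-chlorofuran-2-yl and thiophen-3-yl groups unchanged, this shows that the group at this one position can by itself move the number beyond the scatter, which no earlier pair could show. The step is a minimum, because compound 2 stands at a limit rather than at a measured number: the limit of > 50000 nM in this assay, at which 1 of the 3 values shown sits.

The compounds shown cannot separate the part played by the chlorine from that of the six-membered ring replacing the five-membered one. Also open, as far as these compounds go, is how a phenyl without chlorine, or a phenyl carrying an amine or a carboxylic acid in its place, would read in this assay.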